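A few compounds are considered here, and "the series" means these few. Any claim that something is new, unique, unknown or untested is made for them only; others in the source may bear on it.

Measured so far:
Compound 1, `CC[C@H](F)[C@H](C)O`: in a physicochemical assay for lipophilicity, read by NMR (a higher number here means a more lipophilic compound, a lower number a more polar compound), compound 1 gives 0.68.
Compound 2, `CCCC(O)CF`: in this assay compound 2 gives 0.74.

Compound 1 holds the lower of the two numbers, but its nearest neighbour, compound 2, stands only a little higher, and that gap lies within the usual scatter of repeated measurements, so the two values cannot be told apart. For the measured compounds named here, no step between measured compounds differing in one place has been recorded, so there is nothing in the data to calibrate a change against.

The compound still to be measured is compound 3, `CC[C@@H](F)[C@H](C)O`. Set against compound 1, the difference is this: the two compounds have the same atoms and bonds and differ only in configuration as drawn: 1 of 2 stereo elements differ; a stereocentre at a saturated chain carbon is drawn S in compound 1 and R in compound 3. Nothing leaves and nothing enters; the change is one of configuration as drawn alone. The two measured compounds offer no guide to what such a change does in this assay. The expectation is therefore a step of no size beyond the scatter, in no particular direction, no change at the digits printed from compound 1 to compound 3 (within the scatter). Compound 3 is expected to give 0.68, with a range from 0.38 to 0.98.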

Compound 3, partition coefficient: 0.68
Compound 3: the middle estimate sits on the measured number at the digits printed; the measured number falls inside the stated range.
By their numbers in this assay, from the lowest: compounds 1, 3 and 2 (each within the scatter of the next).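

With compound 3, the study holds its first step between measured compounds that differ in one place, and in this assay that step reads no change at the digits printed from compound 1 to compound 3 (within the scatter). Where the earlier compounds offered nothing to calibrate a change against, this pair shows that, for these two compounds, drawing this stereocentre on the saturated chain as S or as R gives no difference that this assay can resolve, while the other stereo element stays as drawn. The pair can be read as a test of configuration alone, with nothing leaving and nothing entering, because of one thing: the fact that compounds 1 and 3 differ only in the configuration as drawn

The compounds shown leave open whether the other stereo element, or both stereo elements drawn the opposite way together, would read the same, since this single pair speaks only for the one stereocentre that differs in it. They also leave open whether a change of configuration at this carbon would stay as small in a compound carrying an amine, a carboxylic acid or a longer chain.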